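Acylating the Amine of a Long-Chain Threonine Amide

The compounds below may be only part of what the source reports. "The series", "measured", "known", "first", "only" and "open" are said of these compounds alone.

Of the compounds shown here, three have been measured in a functional assay on SW-620 cells (Homo sapiens) for cytotoxicity, read by MTT assay, with a stated time of 48 h; on this read-out lower numbers stand for stronger inhibition and higher numbers for weaker inhibition. Compound 1 `CCCCCCCCCCCCCCNC(=O)[C@@H](N)[C@@H](C)O` gives 18700 nM, compound 2 `CCCCCCCCCCCCCCCCCCNC(=O)[C@@H](N)[C@@H](C)O` gives 21400 nM, and compound 3 `CCCCCCCCNC(=O)[C@@H](NC(=O)c1ccccc1)[C@@H](C)O` gives 200000 nM. Compound 2 stands second highest of the three numbers; its nearest neighbour is compound 1, and its furthest is compound 3. Among the compounds with values here, the only step between compounds differing in one place is a 1.1-fold higher number from compound 1 to compound 2 (0.06 log units; within the scatter), so lengthening the chain changed little.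

Compound 4 `CCCCCCCCCCCCCCCCCCNC(=O)[C@@H](NC(=O)c1nccc2ccccc12)[C@@H](C)O` carries (isoquinolin-1-yl)carbonyl in place of hydrogen on an amine nitrogen. Within the data shown here, no measured step isolates this change. Compound 3, however, also has an acyl group on its amine nitrogen, together with a shorter chain, and its number is the highest of the three, while chain length on its own mattered little. An acylated amine is therefore expected to raise the number in this assay by a sizeable step, roughly a 3.7-fold higher number from compound 2 to compound 4 (0.57 log units; beyond the scatter).

Compound 4 is thus estimated at 80000 nM, within a range from 25000 nM to 250000 nM.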

Compound 4, half-maximal inhibitory concentration: 136000 nM
For compound 4 the middle estimate is 1.7-fold (0.23 log units) below the measured one; the measured number falls inside the stated range.
By their numbers in this assay, from the lowest: compounds 1 and 2 (each within the scatter of the next); then compounds 4 and 3 (each within the scatter of the next).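

In this assay, replacing a hydrogen on the amine nitrogen with (isoquinolin-1-yl)carbonyl gives a 6.4-fold higher number from compound 2 to compound 4 (0.80 log units; beyond the scatter) while the long chain stays the same, so the number moves clearly upward and inhibition is weaker. Within the data shown here, this is the first comparison in which a change at this nitrogen stands alone, since compound 3 also differs from the free amines in its chain. The data offer no measurement that explains the rise.

On these data alone, it remains open whether the step comes from the carbonyl or from the two-ring isoquinoline part, which a small acetyl group or a benzoyl group on the same long chain would help to separate. Also open, as far as these compounds go, is how a simple methyl group on this nitrogen, which keeps the amine rather than forming an amide, would compare.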